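Swapping the Basic Amine on a Shortened Chain

The source may hold more compounds than are shown below. What is called first, only, known or untested is meant among the compounds shown, and "the series" means these compounds.

Compound 1 `CN1CCN(CCCCOc2c(O)cc3oc(-c4ccccc4)cc(=O)c3c2O)CC1` gives in a functional assay on A549 cells (Homo sapiens) for antiproliferative activity, read by MTT assay, with a stated time of 48 h (a lower number here means a stronger inhibitor, a higher number a weaker inhibitor), only the assay limit > 100000 nM.
Compound 2 `CCN(CC)CCCCOc1c(OCc2ccccc2)cc2oc(-c3ccccc3)cc(=O)c2c1O` gives in this assay 1800 nM.
Compound 3 `CN1CCN(CCCCOc2c(OCc3ccccc3)cc3oc(-c4ccccc4)cc(=O)c3c2O)CC1` gives in this assay 4400 nM.

Compound 2 holds the lowest of the two numbers shown; its nearest neighbour is compound 3, with a 2.4-fold higher number from compound 2 to compound 3 (0.39 log units; beyond the scatter). Compound 4 `CN1CCN(CCCOc2c(OCc3ccccc3)cc3oc(-c4ccccc4)cc(=O)c3c2O)CC1` differs from compound 2 by 4-methylpiperazin-1-yl in place of (diethylamino)methyl on a saturated chain carbon, three bonds along the chain from an oxygen on an aromatic ring. The amine exchange itself is the same as in the measured step of a 2.4-fold higher number from compound 2 to compound 3 (0.39 log units; beyond the scatter), a modest rise. The step of an at least 22-fold lower number from compound 1 to compound 3 (1.35 log units; beyond the scatter) concerns the benzyl group, which compound 2 and compound 4 both carry, so it does not bear here. For the measured compounds named here, the chain shortening has no measured counterpart. Compound 4 is therefore expected to give about 5000 nM, within 2000 nM to 15000 nM. The expected step of a 2.8-fold higher number from compound 2 to compound 4 (0.44 log units; beyond the scatter) is modest, toward a higher number.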

Compound 4, half-maximal inhibitory concentration: 1300 nM
Estimate against measurement, compound 4: 3.8-fold (0.59 log units) above, outside the stated range (below it).
By their numbers in this assay, from the lowest: compounds 4 and 2 (each within the scatter of the next); then compound 3. At a limit, above all of these: compound 1.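

In this assay, chain length matters at this position: keeping the 4-methylpiperazin-1-yl group and moving to the 3-(4-methylpiperazin-1-yl)propyl chain gives a 3.4-fold lower number from compound 3 to compound 4 (0.53 log units; beyond the scatter), a change that the amine exchange alone did not predict. Changing the amine and the chain together gives a 1.4-fold lower number from compound 2 to compound 4 (0.14 log units; within the scatter), so these two compounds cannot be told apart here. As far as these compounds go, whether a 3-(diethylamino)propyl chain would also gain, and how a shorter 2-(4-methylpiperazin-1-yl)ethyl chain or a morpholine would fare, stays open. Nothing shown here explains the effect of chain length.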